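The source may hold more compounds than are shown below. What is called first, only, known or untested is meant among the compounds shown, and "the series" means these compounds.

Measured in a functional assay on HCT-116 cells (Homo sapiens) for inhibition, read by MTT assay, with a stated time of 48 h; on this read-out higher numbers stand for weaker inhibition and lower numbers for stronger inhibition:
- compound 1 `C/C=C/C(=O)N(Cc1ccc(OC)c(OC)c1)c1cc(OC)c(OC)c(OC)c1`: 32800 nM
- compound 2 `COc1ccc(CN(C(=O)CO)c2cc(OC)c(OC)c(OC)c2)cc1O`: 520 nM

Compound 2 holds the lower of the two numbers, and its gap to compound 1 lies beyond the scatter. Compound 3 `C/C=C/C(=O)N(Cc1ccc(OC)c(O)c1)c1cc(OC)c(OC)c(OC)c1` has prop-1-en-1-yl in place of hydroxymethyl on a carbonyl carbon. Going by the values given here, no measured pair shows this change alone. Compound 1 also carries prop-1-en-1-yl there and gives 32800 nM, so weaker inhibition is expected. The expected size of the change is a 5.8-fold higher number from compound 2 to compound 3 (0.76 log units; beyond the scatter), beyond the scatter. The estimated value for compound 3 is 3000 nM, within an expected range of 500 nM to 20000 nM.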

Compound 3, half-maximal inhibitory concentration: 55 nM
The estimate for compound 3 lay 55-fold (1.74 log units) above the measured number; measured number below the stated range.
By their numbers in this assay, from the lowest: compound 3; then compound 2; then compound 1.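

In this assay, prop-1-en-1-yl on a carbonyl carbon gives stronger inhibition than hydroxymethyl (a 9.5-fold lower number from compound 2 to compound 3 (0.98 log units; beyond the scatter)), so this group is compatible with a low number. Compound 1 carries the same group, yet hydrogen in place of methyl on an oxygen on an aromatic ring produces a far larger gain (a 600-fold lower number from compound 1 to compound 3 (2.78 log units; beyond the scatter)), tying its weak number to that methyl. No available evidence explains either step. Still open, on these data alone, is whether an amine or a longer chain on the carbonyl carbon would match prop-1-en-1-yl, and whether ethyl on that oxygen would weaken inhibition as methyl does.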